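Replacing the hydroxyamino terminus with trifluoromethyl

A few compounds are considered here, and "the series" means these few. Any claim that something is new, unique, unknown or untested is made for them only; others in the source may bear on it.

Measured so far in an assay on isolated protein for inhibition of histone deacetylase 8 (Homo sapiens), read by fluorescence, with a stated time of 10 min; a higher number here means a weaker inhibitor, a lower number a stronger inhibitor:
Compound 1 `Cc1ccc(-c2noc(CCCCCCC(=O)NO)n2)cc1` gives 5390 nM.
Compound 3 `O=C(CCCCCCc1nc(-c2cccs2)no1)NO` gives 1920 nM.
Compound 2 `O=C(CCCCCCc1nc(-c2ccc(C(F)(F)F)cc2)no1)NO` reaches > 10000 nM, which is a limit and not a number.

Compound 1 holds the highest of the two numbers; its nearest neighbour is compound 3, with a 2.8-fold lower number from compound 1 to compound 3 (0.45 log units; beyond the scatter). The change to compound 2 gives an at least 1.8-fold higher number from compound 1 to compound 2 (0.26 log units; that floor lies within the scatter), ending at the limit of > 10000 nM in this assay, at which 1 of the 3 values shown sits. Compound 4 `Cc1ccc(-c2noc(CCCCCCC(=O)C(F)(F)F)n2)cc1` differs from compound 1 by trifluoromethyl in place of hydroxyamino on a carbonyl carbon. Among the measured compounds shown here, both measured steps change the aryl group on the shared core and leave the chain terminus untouched, so neither bears on this change, and no measured step sets its size. The expected step is a 3.7-fold higher number from compound 1 to compound 4 (0.57 log units; beyond the scatter), towards a higher number. Compound 4 is estimated at 20000 nM, within 3000 nM to 100000 nM, with a fair chance that this assay reports only a limit.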

Compound 4, half-maximal inhibitory concentration: 3190 nM
Beside the measured number, compound 4's estimate is 6.3-fold (0.80 log units) above it, within the range that was stated.
By their numbers in this assay, from the lowest: compounds 3, 4 and 1 (each within the scatter of the next, the first and the last beyond it). At a limit, above all of these: compound 2.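

This is the first step shown at the chain terminus rather than on the aryl group. In this assay, trifluoromethyl in place of hydroxyamino on a carbonyl carbon gives a 1.7-fold lower number from compound 1 to compound 4 (0.23 log units; within the scatter), so the hydroxyamino group is not needed for a measurable value in this series. Nothing shown accounts for this result.

Open, on these data alone, is whether the same swap reads alike on the thiophen-2-yl analogue, compound 3. Also open, as far as these compounds go, is how a carboxylic acid or a primary amide at this terminus, or a longer chain, would read.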